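This account rests on a few compounds, and the source may have more. Where it says the series, first, only, none or still open, it means among the compounds named here.

Measured in a functional assay on MCF-10A cells (Homo sapiens) for antiproliferative activity, with a stated time of 48 h; a higher number here means that more compound is needed for the effect, a lower number that less compound is needed:
Compound 1 `COc1ccc(CNc2cc(C)nc3ccc(OC)cc23)cc1`: 9700 nM
Compound 2 `COc1cccc(CNc2cc(C)nc3ccc(OC)cc23)c1`: 12500 nM
Compound 3 `COc1ccc2nc(C)cc(NCc3ccc(OC(F)F)cc3)c2c1`: 14700 nM

All three compounds share one core. Compound 1 and compound 2 are built from the same atoms joined differently; the difference between the two cores is not broken down here, and their values in this assay lie within the scatter of each other. From compound 1 to compound 3 the change difluoromethyl in place of methyl on an oxygen on an aromatic ring gave a 1.5-fold higher number from compound 1 to compound 3 (0.18 log units; within the scatter), a step that stays within the scatter.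

Compound 4 `COc1ccc2nc(C)cc(NCc3cccc(OC(F)F)c3)c2c1` applies the same change to compound 2: difluoromethyl in place of methyl on an oxygen on an aromatic ring. The place of the change is described in the same words in both cases, so this is the same change. Because the earlier step was a 1.5-fold higher number from compound 1 to compound 3 (0.18 log units; within the scatter), compound 4 is expected to show a step of about a 1.4-fold higher number from compound 2 to compound 4 (0.16 log units; within the scatter) in this assay. The estimate for compound 4 is therefore 18000 nM, expected to fall between 9000 nM and 36000 nM.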

Compound 4, half-maximal effective concentration: 14300 nM
Estimate against measurement, compound 4: 1.3-fold (0.10 log units) above, and the stated range covers the measured number.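

Putting difluoromethoxy in place of methoxy on the core of compound 2 gave a 1.1-fold higher number from compound 2 to compound 4 (0.06 log units; within the scatter) in this assay. Set beside the earlier step, the same change gives steps that do not differ between the two cores: the same change on two cores in this assay, a 1.5-fold higher number (0.18 log units; within the scatter) from compound 1 to compound 3 and a 1.1-fold higher number (0.06 log units; within the scatter) from compound 2 to compound 4, 1.3-fold (0.12 log units) apart, within the scatter of two such steps This shows that the change carried from one core to the other without a readable difference, but both steps stay within the scatter, so it does not show that the change itself has any effect, nor how it would behave on a third core.

The compounds shown leave open whether a different group in place of the methoxy, such as an amine, a carboxylic acid or a longer chain, would move the number beyond the scatter.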